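This account rests on a few compounds, and the source may have more. Where it says the series, first, only, none or still open, it means among the compounds named here.

Measured so far in an ADME assay on L132 cells (Homo sapiens) for cytotoxicity, read by MTT assay, with a stated time of 48 h; on this read-out higher numbers stand for weaker inhibition and lower numbers for stronger inhibition:
- Compound 1 `C/C(=C\CC/C(C)=C/CC[C@@H]1[C@@]2(C)CCC(=O)C(C)(C)[C@H]2CC[C@@]1(C)O)CC/C=C(\C)C(=O)OCc1cn(-c2ccccc2C)nn1`: > 150000 nM, a limit of the assay
- Compound 2 `C/C(=C\CC/C(C)=C/CC[C@@H]1[C@@]2(C)CCC(=O)C(C)(C)[C@H]2CC[C@@]1(C)O)CC/C=C(\C)C(=O)OCc1cn(-c2cccc(Br)c2)nn1`: > 150000 nM, a limit of the assay
- Compound 3 `C/C(=C\CC/C(C)=C/CC[C@@H]1[C@@]2(C)CCC(=O)C(C)(C)[C@H]2CC[C@@]1(C)O)CC/C=C(\C)C(=O)OCc1cn(-c2cccc(Cl)c2)nn1`: 94200 nM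

Among the compounds with values here, compound 3 holds the only actual number in this small set. The other two results stop at the limit of > 150000 nM in this assay, at which 2 of the 3 values shown sit.

Compound 4 `C/C(=C\CC/C(C)=C/CC[C@@H]1[C@@]2(C)CCC(=O)C(C)(C)[C@H]2CC[C@@]1(C)O)CC/C=C(\C)C(=O)OCc1cn(-c2ccccc2)nn1` carries hydrogen in place of chloro on an aromatic carbon, so 3-chlorophenyl becomes phenyl. Within the data shown here, two measured steps bear on this change, as both alter the same aromatic group: an at least 1.5-fold lower number from compound 1 to compound 3 (0.20 log units; that floor lies within the scatter) and an at least 1.5-fold lower number from compound 2 to compound 3 (0.20 log units; that floor lies within the scatter). Each gives only a floor for the size of the step. The third comparison, a step that the two limits leave unreadable from compound 1 to compound 2, adds nothing readable.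

These swaps therefore show no firm effect, and no step beyond the scatter is expected in this assay. The expected change is a 1.3-fold higher number from compound 3 to compound 4 (0.11 log units; within the scatter), a small rise toward the limit. A report of only a limit would be no surprise. For compound 4 the estimated value is 120000 nM, with an expected range from 70000 nM to 200000 nM.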

Compound 4, half-maximal inhibitory concentration: > 150000 nM
Compound 4: a limit, no number; the forecaster's own chance of this, stated with the estimate: 45%; middle value at least 1.2-fold (0.09 log units) away from the limit.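

Taking the chloro off, so that 3-chlorophenyl becomes phenyl, gives in this assay an at least 1.5-fold higher number from compound 3 to compound 4 (0.20 log units; that floor lies within the scatter), which means the ring with no substituent at this place can be judged only by a floor, and that floor shows no firm effect of the chloro. The steps from compound 1 and from compound 2 to compound 4 join two limits and cannot be read. Compound 3 therefore remains the only one of the set with an actual number, and the plain phenyl joins the others at the limit: the limit of > 150000 nM in this assay, at which 3 of the 4 values shown sit.

Still open, going by these compounds, is how far past that limit compound 1, compound 2 and compound 4 lie, and so whether the chloro makes a real difference at all. On these data alone, it is also open what an amine or a carboxylic acid in place of the chloro would do in this assay.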